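This account rests on a few compounds, and the source may have more. Where it says the series, first, only, none or still open, it means among the compounds named here.

Measured so far:
compound 1 `O=C(Cn1c(-c2ccccc2)cc(-c2ccccc2)c1-c1ccccc1)Nc1ccccn1` — < 50000 nM
compound 2 `O=C(Cn1c(-c2ccccc2)cc(-c2ccccc2)c1-c1ccc(Br)cc1)Nc1nc2ccccc2s1` — < 50000 nM

In an ADME assay on HEK-293T cells (Homo sapiens) for cytotoxicity, read by MTT assay, with a stated time of 72 h (on this read-out higher numbers stand for weaker inhibition and lower numbers for stronger inhibition), compound 1 gives < 50000 nM, which is a limit of the assay and not a number. Compound 2 likewise gives < 50000 nM in this assay, again a limit. Both values shown sit at the same limit (the limit of < 50000 nM in this assay, at which 2 of the 2 values shown sit). Compound 3 `O=C(Cn1c(-c2ccccc2)cc(-c2ccccc2)c1-c1ccc(Br)cc1)Nc1ccccn1` has not yet been measured; it differs from compound 2 by pyridin-2-yl in place of 1,3-benzothiazol-2-yl on an amide-type nitrogen. Within the data shown here, with no step between measured compounds given, no direction can be read from the data, and a step no larger than the usual scatter is expected a step that the limit leaves unreadable from compound 2 to compound 3. Compound 3 is estimated at 20000 nM, between 5000 nM and 50000 nM.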

Compound 3, half-maximal inhibitory concentration: < 50000 nM
Compound 3: no number, only a limit (the forecaster's own chance of this, stated with the estimate: 70%); the middle value lies beyond the limit too.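

Compound 3 gives < 50000 nM in this assay, which is a limit of the assay and not a number. No step from compound 1 or compound 2 to compound 3 can be read, because all the values sit at one limit: the limit of < 50000 nM in this assay, at which 3 of the 3 values shown sit.

As far as these compounds go, what the bromo and pyridin-2-yl changes among compound 1, compound 2 and compound 3 do to the actual values stays open.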